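Fluorines in Place of Chlorine: Compound 3 to Compound 4

The source may report more compounds than this note shows. Statements on the series, on what has been measured and on what is new or still open speak of the compounds shown alone.

Compound 1, `N#CC1=C(N)Oc2c(c3nc4ccccc4nc3c3ccccc23)C12C(=O)N(Cc1cnnn1-c1ccccc1Cl)c1ccccc12`, in an ADME assay on HUVEC cells (Homo sapiens) for antiproliferative activity, read by MTT assay, with a stated time of 48 h (on this read-out lower numbers stand for stronger inhibition and higher numbers for weaker inhibition), gives > 50000 nM, a limit of the assay.
Compound 2, `CCOc1ccc(-n2nncc2CN2C(=O)C3(C(C#N)=C(N)Oc4c3c3nc5ccccc5nc3c3ccccc43)c3ccccc32)cc1`, gives > 50000 nM in this assay, again a limit.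
Compound 3, `N#CC1=C(N)Oc2c(N)cc3nc4ccccc4nc3c2C12C(=O)N(Cc1cnnn1-c1ccccc1Cl)c1ccccc12`, gives > 50000 nM in this assay, also a limit.

None of the three measured compounds gives a number in this assay; each sits at the same limit, (the limit of > 50000 nM in this assay, at which 3 of the 3 values shown sit). Among the measured compounds shown here, the one measured step, a step that the two limits leave unreadable from compound 1 to compound 2, is therefore unreadable, and compound 3 stands where compounds 1 and 2 stand, at the limit and no further.

Compound 4, `N#CC1=C(N)Oc2c(N)cc3nc4ccccc4nc3c2C12C(=O)N(Cc1cnnn1-c1c(F)cccc1F)c1ccccc12`, is the one yet to be measured. It differs from compound 3 by 2,6-difluorophenyl in place of 2-chlorophenyl on an aromatic nitrogen. For the measured compounds named here, the only comparison that bears on a change at this aromatic nitrogen is the step from compound 1 to compound 2, and that step shows no readable size, because the limit of > 50000 nM in this assay, at which 3 of the 3 values shown sit, holds both of its ends. No shown step gives a reason to expect compound 4 to leave the limit, so the step that the limit leaves unreadable from compound 3 to compound 4 is expected to lie within the scatter. Compound 4 is estimated at 60000 nM, with a range of 25000 nM to 150000 nM, most likely reported again only as a limit.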

Compound 4, half-maximal inhibitory concentration: > 50000 nM
Compound 4: only a limit was reported (the forecaster's own chance of this, stated with the estimate: 85%); the middle value lies beyond the limit too.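

The step from compound 3 to compound 4 cannot be read, because both compounds stand at the same limit: the limit of > 50000 nM in this assay, at which 4 of the 4 values shown sit.

The compounds shown leave open whether any group on this aromatic nitrogen, or any change to the shared core, would give a readable number in this assay.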